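Cyclopentyl in place of sec-butyl at the ester oxygen

The source may hold more compounds than are shown below. What is called first, only, known or untested is meant among the compounds shown, and "the series" means these compounds.

Compound 1 `CC1=C(C(=O)OCc2ccccc2)C(c2ccoc2)NC(=O)N1` and compound 2 `CCC(C)OC(=O)C1=C(C)NC(=O)NC1c1ccoc1` share one core and differ only in the group on an oxygen next to a carbonyl group. In an assay on membranes from CHO cells for displacement of a labelled ligand from adenosine receptor A1 (Homo sapiens), read by scintillation counting, with a stated time of 60 min, tested at 1 uM (a lower number here means less inhibition, a higher number more inhibition at the concentration tested (going by the name of the read-out)), compound 1 gives 41%, while compound 2 gives 13%. Going by the values given here, the step of a number 28 percentage points lower from compound 1 to compound 2 (beyond the scatter) shows that sec-butyl in place of benzyl brings the read-out down, so compound 2 stands lowest of the two numbers known, with compound 1 as its only neighbour.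

Compound 3 `CC1=C(C(=O)OC2CCCC2)C(c2ccoc2)NC(=O)N1` differs from compound 2 by cyclopentyl in place of sec-butyl on an oxygen next to a carbonyl group. Among the compounds with values here, no measured step covers this exchange; the single step at hand, from benzyl to sec-butyl, was modest and beyond the scatter, and cyclopentyl, like benzyl, carries a ring. For compound 3 the step of a number 9 percentage points higher from compound 2 to compound 3 (within the scatter) is expected to be small and upward, likely within the scatter. Compound 3 is therefore estimated at 22%, within 5% to 45%.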

Compound 3, a percentage reported as inhibition, at one concentration (the size of the read-out at that concentration, not a potency): 6%
For compound 3 the middle estimate is 16 percentage points above the measured one, and the stated range covers the measured number.
By their numbers in this assay, from the lowest: compounds 3 and 2 (each within the scatter of the next); then compound 1.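

Cyclopentyl in place of sec-butyl on an oxygen next to a carbonyl group gives a number 7 percentage points lower from compound 2 to compound 3 (within the scatter) in this assay, so an open chain and this carbon-only ring cannot be told apart at this position. Cyclopentyl in place of benzyl gives a number 35 percentage points lower from compound 1 to compound 3 (beyond the scatter), which shows that carrying a ring is not enough to hold the read-out up, since of these three groups only benzyl stands apart from the other two. Nothing available explains what sets benzyl apart.

As far as these compounds go, it remains open whether another group on this oxygen, such as a phenylethyl chain or a pyridylmethyl group, would match or pass benzyl. Each number is also the size of the read-out at a single concentration, so these compounds leave their potencies open.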